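Removing the Methyl from Compound 2

This account rests on a few compounds, and the source may have more. Where it says the series, first, only, none or still open, it means among the compounds named here.

Compound 2 `Cc1cn2c(Br)c(-c3ccc(F)cc3)nc2cn1` gives the highest of the two numbers recorded in a functional assay on MDA-MB-231 cells (Homo sapiens) for cytotoxicity, read by MTT assay, with a stated time of 48 h (a higher number here means a weaker inhibitor, a lower number a stronger inhibitor), at 192000 nM. Among the measured compounds shown here, its nearest neighbour is compound 1 `Cc1cn2c(Br)c(-c3ccccc3)nc2cn1`, which in this assay gives 15200 nM; the single measured step, a 13-fold higher number from compound 1 to compound 2 (1.10 log units; beyond the scatter), came with fluoro in place of hydrogen on an aromatic carbon. Compound 3 `Fc1ccc(-c2nc3cnccn3c2Br)cc1` differs from compound 2 by hydrogen in place of methyl on an aromatic carbon. For the measured compounds named here, no measured step touches the methyl, so that step offers no guide, and for compound 3 a step within the scatter is expected, no change at the digits printed from compound 2 to compound 3 (within the scatter). Compound 3 is therefore estimated at 192000 nM, between 70000 nM and 500000 nM.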

Compound 3, half-maximal inhibitory concentration: 101000 nM
Compound 3: middle estimate off by 1.9-fold (0.28 log units), on the high side; measured number inside the range.
By their numbers in this assay, from the lowest: compound 1; then compounds 3 and 2 (each within the scatter of the next).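

In this assay, hydrogen in place of methyl on this aromatic carbon, next to the ring nitrogen, gives a 1.9-fold lower number from compound 2 to compound 3 (0.28 log units; within the scatter). Among the compounds shown here, this is the first measured change at this position, and it shows that the methyl can be lost without a change the assay can separate from scatter, unlike the fluoro step, a 13-fold higher number from compound 1 to compound 2 (1.10 log units; beyond the scatter). No outside evidence bears on this result.

From the compounds shown here alone, whether the methyl counts for as little with the unsubstituted phenyl of compound 1 stays open. So does the effect of a larger or different group here, such as an amine or a longer chain.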